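This account rests on a few compounds, and the source may have more. Where it says the series, first, only, none or still open, it means among the compounds named here.

Four closely related compounds, built on the same shared core, are compared for how strongly they hold back the growth of a human lung cancer cell line in a functional assay on A549 cells (Homo sapiens) for antiproliferative activity, read by MTT assay, with a stated time of 48 h; a higher number here means a weaker inhibitor, a lower number a stronger inhibitor. Compound 1 `O=C1Nc2ccccc2[C@]12N[C@H](c1ccccc1)[C@H](c1ccccc1)[C@@]21CCc2c([nH]c3ccc(Cl)cc23)C1=O` gives 15000 nM in this assay. Compound 2 `O=C1Nc2ccccc2[C@]12N[C@H](c1ccccc1)[C@H](c1ccccc1)[C@@]21CCc2c([nH]c3ccccc23)C1=O` differs from compound 1 by hydrogen in place of chloro on an aromatic carbon, and in this assay compound 2 gives 17000 nM. That change produced a step of a 1.1-fold higher number from compound 1 to compound 2 (0.05 log units; within the scatter). Compound 3 `COc1ccc([C@H]2[C@@H](c3ccccc3)N[C@@]3(C(=O)Nc4ccccc43)[C@]23CCc2c([nH]c4ccc(Cl)cc24)C3=O)cc1` differs from compound 1 by methoxy in place of hydrogen on an aromatic carbon, and in this assay compound 3 gives 18000 nM, a step of a 1.2-fold higher number from compound 1 to compound 3 (0.08 log units; within the scatter). The three measured numbers therefore sit close together, and none of the three can be called stronger or weaker than the others.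

Compound 4 `COc1ccc([C@H]2[C@@H](c3ccccc3)N[C@@]3(C(=O)Nc4ccccc43)[C@]23CCc2c([nH]c4ccccc24)C3=O)cc1` has not yet been measured. It differs from compound 3 by hydrogen in place of chloro on an aromatic carbon, which is the same change that turned compound 1 into compound 2. The core on which it is made is that of compound 3 rather than compound 1, and the two cores differ by methoxy in place of hydrogen on an aromatic carbon. A similarly small step is expected in this assay because a 1.1-fold higher number from compound 1 to compound 2 (0.05 log units; within the scatter) stayed within the usual scatter. From compound 3 to compound 4 a step of a 1.1-fold higher number from compound 3 to compound 4 (0.05 log units; within the scatter) is expected. Compound 4 is therefore estimated to give 20000 nM in this assay, with a likely range from 10000 nM to 40000 nM.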

Compound 4, half-maximal inhibitory concentration: 21000 nM
Beside the measured number, compound 4's estimate is 1.1-fold (0.02 log units) below it; low and high end bracket the measured number.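

Putting hydrogen in place of chloro on the core of compound 3 gives a 1.2-fold higher number from compound 3 to compound 4 (0.07 log units; within the scatter) in this assay, and this small step agrees with the one seen for the same change on the core of compound 1: the same change on two cores in this assay, a 1.1-fold higher number (0.05 log units; within the scatter) from compound 1 to compound 2 and a 1.2-fold higher number (0.07 log units; within the scatter) from compound 3 to compound 4, 1.0-fold (0.01 log units) apart, within the scatter of two such steps

Putting methoxy in place of hydrogen gives a 1.2-fold higher number from compound 2 to compound 4 (0.09 log units; within the scatter), and this step likewise agrees with its earlier counterpart: the same change on two cores in this assay, a 1.2-fold higher number (0.08 log units; within the scatter) from compound 1 to compound 3 and a 1.2-fold higher number (0.09 log units; within the scatter) from compound 2 to compound 4, 1.0-fold (0.01 log units) apart, within the scatter of two such steps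

Each change therefore behaves alike on the two cores shown, but every one of these steps lies within the usual scatter, so the agreement only means that neither change produced a measurable effect on either core, and it does not show that chloro or methoxy matters for growth inhibition, nor that a change with a clear effect would carry over in the same way.

The compounds shown leave open what a quite different group would do at these places, for example an amine or a carboxylic acid in place of the chloro, or a longer chain in place of the methoxy. They also leave open whether changes to the parts kept constant here, such as the remaining phenyl ring, would move the number beyond the scatter.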